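The compounds below may be only part of what the source reports. "The series", "measured", "known", "first", "only" and "open" are said of these compounds alone.

Working notes on the series. Compound 1 `CCCC(=O)c1ccc(OCCCCOc2ccc(C(=O)O)cc2C)c(C)c1O` has been run in an assay on HEK293 cells for positive allosteric modulation of metabotropic glutamate receptor 3 (Rattus norvegicus), read by thallium flux, with a stated time of 2.5 min (a lower number here means a smaller maximal response, a higher number a larger maximal response), and compound 1 gives 40.5%. That is the highest of the three numbers recorded so far. Compound 3 `Cc1cc(OCCCCOc2ccc(C(=O)CC3CCCC3)c(O)c2C)ccc1C(=O)O` gives 23.7% in this assay, a value that sits below compound 1 by a margin beyond the scatter. Compound 2 `CCC(=O)c1ccc(OCCCCOc2ccc(F)c(C(=O)O)c2)c(C)c1O` gives 18.4%, the furthest from compound 1 and again beyond the scatter. Compound 2 and compound 3 lie within the scatter of each other, so nothing is said about their order.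

Compound 4 `CC(=O)c1ccc(OCCCCOc2ccc(C(=O)O)cc2C)c(C)c1O` is the next member and is not yet measured. It differs from compound 1 by hydrogen in place of ethyl on a saturated chain carbon bound to a carbonyl carbon. For the measured compounds named here, no pair of measured compounds differs in one place, so no single-point step is available to lean on; the two other compounds both carry other differences from compound 1 and both sit lower than it, which gives no clear read on this change alone. The expectation for compound 4 is a moderate fall in maximal response, on the edge of the scatter or somewhat beyond it, a step of a number 10.5 percentage points lower from compound 1 to compound 4 (beyond the scatter). Compound 4 is accordingly estimated at 30%, with a range from 16% to 46%.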

Compound 4, largest response reached (reported as percent of maximum), in percent of the reference or control that the assay uses: 25.4%
Beside the measured number, compound 4's estimate is 4.6 percentage points above it; low and high end bracket the measured number.
By their numbers in this assay, from the lowest: compounds 2, 3 and 4 (each within the scatter of the next); then compound 1.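

For the compounds shown here, this is the first comparison that isolates one place. In this assay, cutting the propylcarbonyl of compound 1 back to the acetyl of compound 4, with hydrogen in place of ethyl on a saturated chain carbon bound to a carbonyl carbon, gives a number 15.1 percentage points lower from compound 1 to compound 4 (beyond the scatter). The maximal response therefore depends on this chain even though the rest of the structure is unchanged and the ethyl that leaves has no ring, no hydrogen-bond donors or acceptors and no net charge. No measurement is available that would explain the step.

From the compounds shown here alone, with only propyl and methyl compared directly on this core, the trend cannot yet be extended, and it remains open whether a butyl or a longer chain would raise the response further, hold it or lower it. Going by these compounds, the step has also been read on the core of compound 1 alone, so it remains open whether the same shortening would have a similar effect on the core of compound 2 or compound 3.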